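Cyano in place of methyl on the benzyl group

The source may report more compounds than this note shows. Statements on the series, on what has been measured and on what is new or still open speak of the compounds shown alone.

Measured compounds:
- compound 1, `CC(C)(C)c1cc(CCC(=O)NCCC2CCN(Cc3ccccc3)CC2)cc(C(C)(C)C)c1O`, 46900 nM
- compound 2, `CC(C)(C)c1cc(/C=C/C(=O)NC2CCN(Cc3ccccc3)CC2)cc(C(C)(C)C)c1O`, 33500 nM
- compound 3, `Cc1ccc(CN2CCC(CCNC(=O)/C=C/c3cc(C(C)(C)C)c(O)c(C(C)(C)C)c3)CC2)cc1`, 8900 nM

Of the compounds shown here, three sharing the same phenolic core have been tested in an assay on isolated protein for inhibition of Amine oxidase [flavin-containing] B (Homo sapiens), read by fluorescence, with stated times of 15 min and 20 min; on this read-out lower numbers stand for stronger inhibition and higher numbers for weaker inhibition. Compound 1, with a saturated linker to the amide, gives 46900 nM. Compound 2, carrying an unsaturated linker and a shorter spacer to the piperidine, gives 33500 nM. Compound 3 gives 8900 nM, the lowest of the three numbers; its gap to compound 2 and its gap to compound 1 both lie beyond the scatter, so compound 3 stands as the most potent of the set.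

Compound 4, `CC(C)(C)c1cc(/C=C/C(=O)NCCC2CCN(Cc3ccc(C#N)cc3)CC2)cc(C(C)(C)C)c1O`, has not yet been measured in this assay. It differs from compound 3 only at the aromatic carbon of the six-membered carbon-only ring, para to the large group: cyano in place of methyl on an aromatic carbon. Within the data shown here, no pair of measured compounds separated by this kind of change is available, so the size of the step cannot be read from the data. The expectation is a small step, a 1.3-fold higher number from compound 3 to compound 4 (0.13 log units; within the scatter), not clearly beyond the scatter in either direction. Compound 4 is therefore estimated at 12000 nM, within a range of 4000 nM to 40000 nM.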

Compound 4, half-maximal inhibitory concentration: 13900 nM
Compound 4: the middle estimate sits 1.2-fold (0.06 log units) below what was measured; measured number inside the range.
By their numbers in this assay, from the lowest: compounds 3 and 4 (each within the scatter of the next); then compounds 2 and 1 (each within the scatter of the next).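

In this assay, putting cyano in place of methyl on the aromatic carbon para to a large group gives a 1.6-fold higher number from compound 3 to compound 4 (0.19 log units; within the scatter), so the two compounds cannot be told apart on this read-out. Among these compounds, this is the first reading at this position, since compounds 1 and 2 differ from compound 3 in more than one place; it shows that a group of two heavy atoms with a triple bond and a hydrogen-bond acceptor can stand where a single carbon with no acceptor stood, without a step beyond the scatter, and that 4-cyanobenzyl and 4-methylbenzyl sit at the same level here. No measurement at hand bears on why the two values lie so close.

With only these two groups to compare at this carbon, the shown compounds leave open what a hydrogen, a chlorine atom, a methoxy group, an amine or a carboxylic acid would do there. They also leave open whether cyano and methyl would stay this close on a compound with the saturated linker of compound 1 or the shorter spacer of compound 2.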